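This account rests on a few compounds, and the source may have more. Where it says the series, first, only, none or still open, it means among the compounds named here.

Compound 1 `O=c1[nH]cnc2c1c(-c1ccoc1)cn2[C@@H]1O[C@H](CO)[C@@H](O)[C@H]1O` carries a furan-3-yl group on the shared core. In an ADME assay on BJ cells (Homo sapiens), read by MTT assay, with a stated time of 72 h (on this read-out lower numbers stand for stronger inhibition and higher numbers for weaker inhibition), compound 1 gives > 100000 nM, which is a limit of the assay and not a number. Compound 2 `O=c1[nH]cnc2c1c(-c1cccs1)cn2[C@@H]1O[C@H](CO)[C@@H](O)[C@H]1O` has thiophen-2-yl in place of furan-3-yl on an aromatic carbon; in this assay compound 2 gives > 100000 nM, again a limit. Compound 3 `O=c1[nH]cnc2c1c(-c1ccsc1)cn2[C@@H]1O[C@H](CO)[C@@H](O)[C@H]1O` has thiophen-3-yl in place of furan-3-yl on an aromatic carbon; in this assay compound 3 gives > 100000 nM, also a limit. The steps a step that the two limits leave unreadable from compound 1 to compound 2, a step that the two limits leave unreadable from compound 1 to compound 3 and a step that the two limits leave unreadable from compound 2 to compound 3 cannot be sized because of the limit of > 100000 nM in this assay, at which 3 of the 3 values shown sit. Compound 1 thus stands at the limit, as does every other measured value.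

Compound 4 `Nc1nc2c(c(-c3ccoc3)cn2[C@@H]2O[C@H](CO)[C@@H](O)[C@H]2O)c(=O)[nH]1` differs from compound 1 by amino in place of hydrogen on an aromatic carbon. Among the measured compounds shown here, none of the measured steps concerns this change; each exchanges furan-3-yl for thiophen-2-yl or thiophen-3-yl, and each is unreadable. For the measured compounds named here, no measured step therefore bears on the change from compound 1 to compound 4, and no direction or size can be read from the data. Compound 4 is expected to stay at or near the limit, the estimated step being a step that the limit leaves unreadable from compound 1 to compound 4. The estimate for compound 4 in this assay is 150000 nM, expected to fall between 30000 nM and 500000 nM.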

Compound 4, half-maximal inhibitory concentration: 21500 nM
The estimate for compound 4 lay 7.0-fold (0.84 log units) above the measured number; the whole stated range lies above it.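

In this assay, amino in place of hydrogen on an aromatic carbon gives an at least 4.6-fold lower number from compound 1 to compound 4 (0.66 log units; beyond the scatter), and compound 4 is the only compound shown that carries a number and not a limit. Among the compounds shown here, the earlier exchanges of the furan-3-yl group could not be read, so this is the first sign that a change on the shared core moves the read-out, here towards stronger inhibition, and that the position between two ring nitrogen atoms is one where a single added heavy atom can matter. The value of compound 1 is a limit, so the step has a smallest size but no upper one, and the true gap remains unknown: the limit of > 100000 nM in this assay, at which 3 of the 4 values shown sit.

Going by these compounds, whether a methylamino group, a dimethylamino group, a hydroxyl group or a methyl group at this position would lower the number as amino does remains open. So does whether amino would have the same result alongside the thiophen-2-yl group of compound 2 or the thiophen-3-yl group of compound 3, since this single pair speaks only for the furan-3-yl series.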